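A few compounds are considered here, and "the series" means these few. Any claim that something is new, unique, unknown or untested is made for them only; others in the source may bear on it.

In a physicochemical assay for solubility, read by turbidimetry, measured as kinetic solubility, at pH 7.4 (a higher number here means a more soluble compound, a lower number a less soluble compound), compound 1 `NCc1csc(NC(=O)c2cccs2)n1` gives 80 ug/mL. Compound 2 `CC(C)(C)c1cc(C(=O)Nc2nc(CN)cs2)n(Cc2ccc(Cl)cc2)n1` reaches only a limit of the assay, namely > 200 ug/mL. Compound 2 thus stands at the limit of > 200 ug/mL in this assay, at which 1 of the 2 values shown sits. Compound 3 `CC(C)(C)c1ccc(Cn2nc(C(C)(C)C)cc2C(=O)Nc2nc(CN)cs2)cc1` differs from compound 2 by tert-butyl in place of chloro on an aromatic carbon. Going by the values given here, no measured pair shows this change, so the size of the step in this assay is open; a modest move, downward from the limit if any, is expected. Compound 3 is expected to give 100 ug/mL in this assay, between 30 ug/mL and 200 ug/mL. That corresponds to an expected step of an at least 2.0-fold lower number from compound 2 to compound 3 (0.30 log units; that floor lies within the scatter).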

Compound 3, solubility: 10 ug/mL
Compound 3: the middle estimate sits 10-fold (1.00 log units) above what was measured; measured number outside the range, below it.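

Placing tert-butyl instead of chloro on this aromatic carbon gives an at least 20-fold lower number from compound 2 to compound 3 (1.30 log units; beyond the scatter) in this assay. Going by these compounds alone, this is the first sign that the group at this place on the ring can matter in this assay, which compounds 1 and 2 alone could not show. The step is only a floor, since compound 2 stands at a limit of the assay: the limit of > 200 ug/mL in this assay, at which 1 of the 3 values shown sits.

On these data alone, whether a methyl, an amine or a carboxylic acid on this aromatic carbon would keep the number high remains open. So does whether the same change would act alike on another core.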